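The source may report more compounds than this note shows. Statements on the series, on what has been measured and on what is new or still open speak of the compounds shown alone.

Measured so far:
Compound 1 `Nc1cc(N)c2nc(-c3ccccc3)c(NCc3ccc(Cl)c(Cl)c3)nc2c1`: 69200 nM
Compound 2 `COc1ccc(CNc2nc3cc(N)cc(N)c3nc2-c2ccccc2)cc1OC`: 81300 nM

Both compounds were tested in a functional assay on OVCAR-5 cells (Homo sapiens) for inhibition, read by sulforhodamine B assay, with a stated time of 48 h; on this read-out lower numbers stand for higher toxicity in this test and higher numbers for lower toxicity in this test. Compound 1 gives 69200 nM, and compound 2 gives 81300 nM. The two numbers lie close together: a 1.2-fold higher number from compound 1 to compound 2 (0.07 log units; within the scatter). Compound 2 thus has the higher of the two numbers, yet its distance to compound 1 is within the scatter of repeated measurements, so nothing can be said about which of the two is the more toxic in this test.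

Compound 3 `COc1cc(CNc2nc3cc(N)cc(N)c3nc2-c2ccccc2)cc(OC)c1OC` has not yet been measured. It differs from compound 2 in one place: methoxy in place of hydrogen on an aromatic carbon. The new methoxy sits on an aromatic carbon of a six-membered aromatic ring of carbon only, ortho to a methoxy group, meta to a large group and meta to a methoxy group.

Going by the values given here, only one measured step touches this part of the molecule, the exchange of the whole ring substituent pattern from compound 1 to compound 2, and that step was within the scatter. A further small addition on the same ring is therefore expected to move the number little: the expected step is a 1.0-fold higher number from compound 2 to compound 3 (0.02 log units; within the scatter). For compound 3 the estimate in this assay is 85000 nM, with a range from 40000 nM to 180000 nM.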

Compound 3, concentration lethal to 50% of the cells: < 50200 nM
Compound 3: a limit, no number; the forecaster's own chance of this, stated with the estimate: 20%; middle value at least 1.6-fold (0.22 log units) away from the limit.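

In this assay compound 3 carries a limit of the assay and not a number: the limit of < 50200 nM in this assay, at which 1 of the 3 values shown sits. Placing a methoxy on this aromatic carbon, ortho to a methoxy group, gives an at least 1.6-fold lower number from compound 2 to compound 3 (0.20 log units; that floor lies within the scatter), whereas the earlier exchange of 3,4-dichlorophenyl for 3,4-dimethoxyphenyl gave a 1.2-fold higher number from compound 1 to compound 2 (0.07 log units; within the scatter). Going by these compounds alone, this is the first sign that a change on this ring might bring higher toxicity in this test, but only a sign: the step has a floor and no measured size, and that floor lies within the scatter, so the result fits both a negligible change and a much larger one.

On these data alone, how far compound 3 truly lies from compound 2 stays open, and a version of the compound with a true number in place of the limit would be needed to settle it. Also open, as far as these compounds go, is whether the effect, if real, is tied to methoxy itself, or whether an amine, a hydroxyl or a longer chain such as ethoxy on this same aromatic carbon would give a similar result.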